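Swapping 3-nitrophenyl for 4-methoxyphenyl on a growth inhibitor

The source may report more compounds than this note shows. Statements on the series, on what has been measured and on what is new or still open speak of the compounds shown alone.

- Compound 1 `Nc1ccccc1NC(=O)CCCNCC(=O)Nc1cccc([N+](=O)[O-])c1` gives 15000 nM
- Compound 2 `Nc1ccccc1NC(=O)c1ccc(NCC(=O)Nc2ccc([N+](=O)[O-])cc2)cc1` gives 8200 nM

Both values come from a functional assay on U-251 cells (Homo sapiens) for inhibition, read by MTT assay, with a stated time of 2 days; on this read-out higher numbers stand for weaker inhibition of growth and lower numbers for stronger inhibition of growth. Among the compounds with values here, compound 1 is one of only two measured compounds, and its value lies within the usual scatter of the value of compound 2, so it has no clear rank. Compound 3 `COc1ccc(NC(=O)CNCCCC(=O)Nc2ccccc2N)cc1` has 4-methoxyphenyl in place of 3-nitrophenyl on an amide-type nitrogen. Within the data shown here, no measured pair isolates this swap, so the data give no sign of its direction, and no step beyond the scatter is expected. The estimated step is a 1.1-fold lower number from compound 1 to compound 3 (0.03 log units; within the scatter). For compound 3 the expected value is 14000 nM, with an estimated range of 6000 nM to 32000 nM.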

Compound 3, concentration for 50% growth inhibition: 34000 nM
The estimate for compound 3 lay 2.4-fold (0.39 log units) below the measured number; measured number outside the range, above it.
By their numbers in this assay, from the lowest: compounds 2 and 1 (each within the scatter of the next); then compound 3.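

On the amide-type nitrogen whose other neighbour is the carbonyl carbon, 4-methoxyphenyl in place of 3-nitrophenyl gives a 2.3-fold higher number from compound 1 to compound 3 (0.36 log units; beyond the scatter) in this assay, meaning weaker inhibition of growth. This modest step shows that the group at this place affects the read-out, and that 3-nitrophenyl does better here than 4-methoxyphenyl. No measurement shown accounts for the step.
The compounds shown leave open how a plain phenyl or a 3-methoxyphenyl group would behave at this place. The step therefore cannot yet be divided between the loss of the nitro group and the gain of the methoxy group, or tied to where each sits on the ring.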